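Swapping a Nitro Group for a Nitrile on Sulfonyl

The source may hold more compounds than are shown below. What is called first, only, known or untested is meant among the compounds shown, and "the series" means these compounds.

All compounds here share one core and are judged in a functional assay on SUP-B15 cells (Homo sapiens) for antiproliferative activity, with a stated time of 72 h; on this read-out higher numbers stand for an effect only at larger amounts of compound and lower numbers for an effect already at smaller amounts. Compound 1 `C=CCNC(=O)n1c(-c2ccc(OC)cc2)cc(=O)c2c(OC)cc(OC)cc21` gives 16000 nM. Compound 2 `COc1ccc(-c2cc(=O)c3c(OC)cc(OC)cc3n2S(=O)(=O)c2ccc([N+](=O)[O-])cc2)cc1`, which carries a 4-nitrophenyl on its sulfonyl sulfur, gives 17100 nM. Compound 3 `COc1ccc(-c2cc(=O)c3c(OC)cc(OC)cc3n2S(=O)(=O)c2cccc([N+](=O)[O-])c2)cc1` gives > 39600 nM, and this is a limit of the assay rather than a number (the limit of > 39600 nM in this assay, at which 1 of the 3 values shown sits). The change an at least 2.3-fold higher number from compound 2 to compound 3 (0.36 log units; beyond the scatter) is therefore only known as a lower bound; it stands beyond the scatter.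

Compound 4 `COc1ccc(-c2cc(=O)c3c(OC)cc(OC)cc3n2S(=O)(=O)c2ccc(C#N)cc2)cc1` differs from compound 3 in one place: 4-cyanophenyl in place of 3-nitrophenyl on a sulfonyl sulfur. For the measured compounds named here, because the only measured step, an at least 2.3-fold higher number from compound 2 to compound 3 (0.36 log units; beyond the scatter), shows that moving a nitro group from the 4-position to the 3-position of that phenyl raised the number, a return to a group at the 4-position may bring the value back toward that of compound 2, though the nitrile is a different group and no measured step covers it. Compound 4 is therefore expected to give 25000 nM, within 10000 nM to 60000 nM, meaning an estimated step of an at least 1.5-fold lower number from compound 3 to compound 4 (0.19 log units; that floor lies within the scatter) in this assay.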

Compound 4, half-maximal effective concentration: 7900 nM
The estimate for compound 4 lay 3.2-fold (0.50 log units) above the measured number; measured number below the stated range.
By their numbers in this assay, from the lowest: compound 4; then compounds 1 and 2 (each within the scatter of the next). At a limit, above all of these: compound 3.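

In this assay, the group on the phenyl at this sulfonyl sulfur can now be seen to lower the number, not only raise it: cyano in place of nitro on an aromatic carbon gives a 2.2-fold lower number from compound 2 to compound 4 (0.34 log units; beyond the scatter). The (4-cyanophenyl)sulfonyl group also improves on allylcarbamoyl on the aromatic nitrogen, giving a 2.0-fold lower number from compound 1 to compound 4 (0.31 log units; beyond the scatter), whereas compound 1 and compound 2 lie within the scatter of each other. Against 3-nitrophenyl the change gives an at least 5.0-fold lower number from compound 3 to compound 4 (0.70 log units; beyond the scatter), and this step is only a floor, as compound 3 stands at a limit of the assay: the limit of > 39600 nM in this assay, at which 1 of the 4 values shown sits.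

The compounds shown do not tell whether 3-cyanophenyl on the sulfonyl sulfur would raise the number as 3-nitrophenyl did. From the compounds shown here alone, what 4-aminophenyl or 4-carboxyphenyl would give there also stays open.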